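The source may report more compounds than this note shows. Statements on the series, on what has been measured and on what is new or still open speak of the compounds shown alone.

Compound 1 `COc1ccc(Cl)cc1N1CCN(CCNC(=O)c2cc3ccccc3o2)CC1`: 2340 nM
Compound 2 `COc1ccc(Cl)cc1N1CCN(CCNC(=O)c2cccnc2)CC1`: 2750 nM
Compound 3 `COc1ccc(Cl)cc1N1CCN(CCNC(=O)c2ccncc2)CC1`: 66.1 nM

In a functional assay for antagonist activity at Adrenergic receptor alpha-1 (Rattus norvegicus) (a higher number here means weaker binding, a lower number tighter binding), compound 1 stands second highest of the three numbers. Its nearest neighbour is compound 2, a 1.2-fold higher number from compound 1 to compound 2 (0.07 log units; within the scatter), a step within the scatter; the furthest is compound 3, a 35-fold lower number from compound 1 to compound 3 (1.55 log units; beyond the scatter). Compound 4 `Cc1ccc(N2CCN(CCNC(=O)c3cc4ccccc4o3)CC2)c(C)c1` has not been measured. It differs from compound 1 by 2,4-dimethylphenyl in place of 5-chloro-2-methoxyphenyl on an amine nitrogen in a ring. Within the data shown here, none of the measured steps bears on this change: each of them, including a 42-fold lower number from compound 2 to compound 3 (1.62 log units; beyond the scatter), alters the group on the carbonyl carbon and leaves the ring on the amine nitrogen untouched. The data give no direction for such a change, so the step to compound 4 is expected to be small, a 1.1-fold higher number from compound 1 to compound 4 (0.03 log units; within the scatter), with a wide range. The estimate for compound 4 is 2500 nM, between 500 nM and 12000 nM.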

Compound 4, dissociation constant: 43.7 nM
Estimate against measurement, compound 4: 57-fold (1.76 log units) above, outside the stated range (below it).
By their numbers in this assay, from the lowest: compounds 4 and 3 (each within the scatter of the next); then compounds 1 and 2 (each within the scatter of the next).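

In this assay the ring on the amine nitrogen proves a strong lever: 2,4-dimethylphenyl in place of 5-chloro-2-methoxyphenyl gives a 54-fold lower number from compound 1 to compound 4 (1.73 log units; beyond the scatter), so the number responds to this position as well as to the group on the carbonyl carbon. Both substituents of the ring differ at once, so the step cannot be assigned to either one. Nothing available explains why the step is so large.

On these data alone, whether 2,4-dimethylphenyl acts the same way alongside the pyridin-4-yl group of compound 3 remains open. So does the outcome with an unsubstituted phenyl or a 2-methoxyphenyl ring on that nitrogen.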